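The source may hold more compounds than are shown below. What is called first, only, known or untested is meant among the compounds shown, and "the series" means these compounds.

Compound 1 `Cc1cnc(NC(=O)COc2ccc(/C=C3\SC(=O)NC3=O)cc2)s1` is the point of departure for this account. In a functional assay on HOP-62 cells (Homo sapiens) for cytotoxicity, read by sulforhodamine B assay, with a stated time of 48 h (on this read-out lower numbers stand for stronger inhibition of growth and higher numbers for weaker inhibition of growth), compound 1 gives 30900 nM. Compound 2 `CCCCC1=NC2(CCCC2)C(=O)N1C(=O)COc1ccc(/C=C2/SC(=O)NC2=O)cc1` carries a different group on the amide side of the shared core, and in this assay compound 2 gives 29500 nM, a number that lies within the scatter of the value of compound 1, so the two cannot be told apart on this read-out. Compound 3 `O=C(COc1ccc(/C=C2\SC(=O)NC2=O)cc1)Nc1cccc(C(F)(F)F)c1` was recorded in this assay only as a limit, < 100000 nM, which is the limit of < 100000 nM in this assay, at which 1 of the 3 values shown sits. Compound 4 `O=C(COc1ccc(/C=C2\SC(=O)NC2=O)cc1)Nc1ccccn1` has not yet been measured in this assay. It differs from compound 1 in a single place: pyridin-2-yl in place of 5-methyl-1,3-thiazol-2-yl on an amide-type nitrogen. Going by the values given here, no pair of measured compounds shows the effect of this exchange, so the measured numbers give no direction for it, and the expected step of a 1.0-fold lower number from compound 1 to compound 4 (0.01 log units; within the scatter) is none beyond the scatter. Compound 4 is therefore estimated to give 30000 nM in this assay, with a range from 10000 nM to 90000 nM, and the measurement will show whether that expectation holds.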

Compound 4, concentration for 50% growth inhibition: 2290 nM
For compound 4 the middle estimate is 13-fold (1.12 log units) above the measured one; measured number below the stated range.
By their numbers in this assay, from the lowest: compound 4; then compounds 2 and 1 (each within the scatter of the next).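

Until this exchange, no two measured compounds differed in one place only, so nothing had shown whether the group on this amide-type nitrogen matters in this assay. Replacing 5-methyl-1,3-thiazol-2-yl with pyridin-2-yl gives a 13-fold lower number from compound 1 to compound 4 (1.13 log units; beyond the scatter), so this site responds strongly to the exchange of one aromatic ring for another, here a five-membered aromatic ring with 2 hetero atoms for a six-membered aromatic ring with 1 hetero atom. Compound 3 is recorded only as a limit and so gives no second measured step for comparison: the limit of < 100000 nM in this assay, at which 1 of the 4 values shown sits.

The exchange changes the ring size, the hetero atoms and the methyl group all at once, so the compounds shown do not reveal which of these differences accounts for the step, and they give no reason for it. From the compounds shown here alone, a plain 1,3-thiazol-2-yl group without the methyl, or a pyridin-2-yl ring carrying a methyl group, would help separate these differences, and whether the step holds on any other core also remains open.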